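Cytotoxicity notes on compounds 1 to 4

A few compounds are considered here, and "the series" means these few. Any claim that something is new, unique, unknown or untested is made for them only; others in the source may bear on it.

Three compounds of the shared core have been run in an ADME assay on BJ cells (Homo sapiens) for cytotoxicity, with a stated time of 72 h; on this read-out lower numbers stand for an effect already at smaller amounts and higher numbers for an effect only at larger amounts of compound. Compound 1 `Cc1cc(NC(=O)Nc2ccc([N+](=O)[O-])c(C(F)(F)F)c2)c2ccccc2n1` reaches only the limit of that assay, at > 25000 nM. Compound 3 `Cc1cc(NC(=O)Nc2cc(F)cc(F)c2)c2ccccc2n1` likewise gives only a limit, > 25000 nM. Among the measured compounds shown here, compound 2 `COC(=O)c1cccc(NC(=O)Nc2cc(C)nc3ccccc23)c1` is the single compound with a number rather than a limit, giving 21000 nM in this assay, and so it stands alone as the one measured point against (the limit of > 25000 nM in this assay, at which 2 of the 3 values shown sit). For the measured compounds named here, no step between two measured compounds is available, since none of the three differ in one place only.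

Compound 4 `Cc1cc(NC(=O)Nc2cccc(N(C)C)c2)c2ccccc2n1` is not yet measured. It differs from compound 2 by dimethylamino in place of methoxycarbonyl on an aromatic carbon. The only anchor for it is compound 2 at 21000 nM. The step that is expected, a 1.2-fold higher number from compound 2 to compound 4 (0.08 log units; within the scatter), is none beyond the scatter. For compound 4 the expected value in this assay is 25000 nM, with a range from 12000 nM to 50000 nM, and a fair chance that only a limit is reported.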

Compound 4, half-maximal effective concentration: > 25000 nM
Compound 4: only a limit was reported (the forecaster's own chance of this, stated with the estimate: 60%); the middle value sits exactly at the limit.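

Among the compounds shown here, the first step between compounds that differ in one place sits on an aromatic carbon of a six-membered aromatic ring of carbon only, meta to a large group. In this assay, dimethylamino in place of methoxycarbonyl there gives a step with only a lower bound (an at least 1.1-fold higher number from compound 2 to compound 4 (0.07 log units; that floor lies within the scatter)), and that floor lies within the scatter. Compound 4 gives a limit and not a number, so this change shows no shift beyond the scatter but does not exclude one, and the series stays at its ceiling: the limit of > 25000 nM in this assay, at which 3 of the 4 values shown sit.

How far compound 4 lies past its limit cannot be read in this assay. The compounds shown also leave open whether another group at this position, such as a carboxylic acid or a primary amine, would bring the number clearly lower.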